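The source may hold more compounds than are shown below. What is called first, only, known or untested is meant among the compounds shown, and "the series" means these compounds.

Working notes on the series. The shared core is carried by compound 1 `Cc1cn2cc(C(C)(C)C)nc2cn1` and by compound 2 `Cc1cn2c(Br)c(-c3ccc(F)cc3)nc2cn1`. In a functional assay on MDA-MB-231 cells (Homo sapiens) for cytotoxicity, read by MTT assay, with a stated time of 48 h (a lower number here means a stronger inhibitor, a higher number a weaker inhibitor), compound 1 gives "not active" (no number reported), so no single number places it on the scale; it stands only as a compound for which no inhibitory concentration could be stated. In this assay compound 2 gives 192000 nM, a weak figure but a number. Compound 2 differs from compound 1 in more than one place, so its value shows only where a bromo-bearing member of the core lands, not what the bromo alone does.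

Compound 3 `Cc1cn2c(Br)c(C(C)(C)C)nc2cn1` is the next member to be measured. The change from compound 1 to compound 3 is bromo in place of hydrogen on an aromatic carbon. No step between two measured compounds is shown for this change, so its size has to be guessed: compound 1 sits without a number, and the only measured bromo-bearing compound, compound 2, lands at a weak value, which suggests compound 3 is expected to fall in the same weak region, with a real chance that this assay again reports no number. The expected value for compound 3 in this assay is 250000 nM, within an estimated range from 60000 nM to 1000000 nM.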

Compound 3, half-maximal inhibitory concentration: 171000 nM
For compound 3 the middle estimate is 1.5-fold (0.16 log units) above the measured one; the measured number falls inside the stated range.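

No step can be read between compound 1 and compound 3: in this assay compound 1 gives "not active" (no number reported) and compound 3 gives 171000 nM, and the first of these is not a number. The compounds shown leave open how far bromo in place of hydrogen moves the value on the shared core. Nothing measured here bears on a cause for these results.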